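The compounds below may be only part of what the source reports. "The series", "measured", "known", "first", "only" and "open" are said of these compounds alone.

In an assay on cells for agonist activity at ecdysone receptor (Bombyx mori), read by a luciferase reporter, with a stated time of 24 h (a lower number here means that less compound is needed, a higher number that more compound is needed for the effect), compound 1 `CC(C)(C)N(NC(=O)c1ccccc1)C(=O)c1ccccc1C(F)(F)F` gives 631 nM, compound 2 `COc1ccccc1C(=O)N(NC(=O)c1ccccc1)C(C)(C)C` gives 525 nM, and compound 3 `CC(C)(C)N(NC(=O)c1cccc(C#N)c1)C(=O)c1ccccc1Cl` gives 955 nM. Among the measured compounds shown here, the one measured step, a 1.2-fold lower number from compound 1 to compound 2 (0.08 log units; within the scatter), stays within the scatter. Compound 3 has the highest number of the three, yet its gaps to compound 1 and to compound 2 both fall within the scatter. Compound 4 `CCCCCCC(=O)NN(C(=O)c1ccccc1Cl)C(C)(C)C` follows from compound 3 by hexyl in place of 3-cyanophenyl on a carbonyl carbon. For the measured compounds named here, no measured step bears on this change: the step from compound 1 to compound 2 only swaps one group for another on an aromatic carbon and leaves the aromatic ring in place. For compound 4 a clearly higher number is expected, a 5.2-fold higher number from compound 3 to compound 4 (0.72 log units; beyond the scatter), with wide uncertainty. Compound 4 is estimated at 5000 nM, in the range 1000 nM to 30000 nM.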

Compound 4, half-maximal effective concentration: 741 nM
Beside the measured number, compound 4's estimate is 6.7-fold (0.83 log units) above it; the whole stated range lies above it.
By their numbers in this assay, from the lowest: compounds 2, 1, 4 and 3 (each within the scatter of the next).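

In this assay, hexyl in place of 3-cyanophenyl on a carbonyl carbon gives a 1.3-fold lower number from compound 3 to compound 4 (0.11 log units; within the scatter) and so leaves the number within the scatter. The earlier compounds shown here all carried an aromatic ring at this place, whereas this pair shows that an open chain without a ring can stand there with no change beyond the scatter. Nothing available gives a reason for this result. As far as these compounds go, whether a shorter chain, a longer chain, or a chain ending in an amine or a carboxylic acid would fit equally well stays open.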